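Adding a Butoxycarbonyl Group to a Carbamate Lactone

A few compounds are considered here, and "the series" means these few. Any claim that something is new, unique, unknown or untested is made for them only; others in the source may bear on it.

Compound 1 `C=C1C(=O)OC[C@@H]1CCOC(=O)Nc1ccccc1` is a small lactone joined through a short chain to a carbamate that ends in a plain benzene ring. Going by the values given here, in a functional assay on RAW264.7 cells (Mus musculus) for inhibition, with a stated time of 30 min (on this read-out lower numbers stand for stronger inhibition and higher numbers for weaker inhibition), compound 1 gives 780 nM, the second highest of the three numbers measured so far. Compound 2 `C=C1C(=O)OC[C@@H]1CCOC(=O)Nc1cccc(Br)c1` carries a bromo group on that ring, and in this assay compound 2 gives 840 nM; the step of a 1.1-fold higher number from compound 1 to compound 2 (0.03 log units; within the scatter). Compound 3 `C=C1C(=O)OC[C@H]1CCOC(=O)Nc1ccccc1` has the same atoms and bonds as compound 1 and differs only in how one centre is drawn (the fact that compounds 1 and 3 differ only in the configuration as drawn); in this assay compound 3 gives 390 nM, and the step of a 2.0-fold lower number from compound 1 to compound 3 (0.30 log units; within the scatter).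

Compound 4 `C=C1C(=O)OC[C@@H]1CCOC(=O)Nc1ccc(C(=O)OCCCC)cc1` differs from compound 1 by butoxycarbonyl in place of hydrogen on an aromatic carbon. Among the compounds with values here, no measured step puts in the same group, so the nearest guide is the change from compound 1 to compound 2, where a different group on the same aromatic ring gave a 1.1-fold higher number from compound 1 to compound 2 (0.03 log units; within the scatter). On that basis the step in this assay is expected to stay within the scatter, with no clear direction either way. Compound 4 is therefore expected to give about 750 nM, between 250 nM and 2200 nM. That estimate means an expected step of a 1.0-fold lower number from compound 1 to compound 4 (0.02 log units; within the scatter).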

Compound 4, half-maximal inhibitory concentration: 860 nM
For compound 4 the middle estimate is 1.1-fold (0.06 log units) below the measured one; low and high end bracket the measured number.
By their numbers in this assay, from the lowest: compounds 3, 1, 2 and 4 (each within the scatter of the next, the first and the last beyond it).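

Butoxycarbonyl brings 7 heavy atoms, with no ring and 2 hydrogen-bond acceptors, onto an aromatic carbon para to a large group, and in this assay the result is a 1.1-fold higher number from compound 1 to compound 4 (0.04 log units; within the scatter) for this change. The earlier bromo step already stayed within the scatter, but it involved only a single added atom, so compound 4 extends that finding to a far larger group: on the listed compounds, neither addition to this ring produces a step beyond the scatter. Nothing measured here explains why so large an addition leaves the number within the scatter.

Going by these compounds, it remains open whether an amine, a carboxylic acid or a shorter ester such as methoxycarbonyl at this same ring carbon would also stay within the scatter, and whether a much longer chain would do so. On these data alone, it is equally open whether butoxycarbonyl would give a similarly small step on compound 3, whose stereocentre is drawn the other way.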